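A few compounds are considered here, and "the series" means these few. Any claim that something is new, unique, unknown or untested is made for them only; others in the source may bear on it.

Measured compounds:
compound 1 `O=C(Nc1cc(-c2ccccc2)nn1-c1ccccc1)c1ccc([N+](=O)[O-])cc1` gives 250 nM in an assay on HEK293 cells for displacement of a labelled ligand from metabotropic glutamate receptor 5 (Rattus norvegicus); on this read-out lower numbers stand for stronger inhibition and higher numbers for weaker inhibition
compound 2 `O=C(Nc1cc(-c2ccccc2)nn1-c1ccccc1)C1=CCCCC1` gives 4470 nM in this assay

Compound 2 holds the higher of the two numbers in this assay; its nearest neighbour, compound 1, sits an 18-fold higher number from compound 1 to compound 2 (1.25 log units; beyond the scatter) apart, a large step from 4-nitrophenyl to cyclohex-1-en-1-yl. Compound 3 `O=C(CC1CCCC1)Nc1cc(-c2ccccc2)nn1-c1ccccc1` differs from compound 2 by cyclopentylmethyl in place of cyclohex-1-en-1-yl on a carbonyl carbon. Going by the values given here, no measured step swaps one saturated-type ring for another on the carbonyl carbon, so the only known step does not bear directly on it. The author expects a change within the scatter, a 1.1-fold higher number from compound 2 to compound 3 (0.05 log units; within the scatter), giving compound 3 an estimated 5000 nM with a range of 1500 nM to 16000 nM.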

Compound 3, inhibition constant: > 10000 nM
Compound 3: no number, only a limit (the forecaster's own chance of this, stated with the estimate: 10%); middle value at least 2.0-fold (0.30 log units) from the limit.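

In this assay compound 3 gives > 10000 nM, which is a limit of the assay and not a number. Even so, cyclopentylmethyl and cyclohex-1-en-1-yl, each with 6 carbon atoms, are not interchangeable on the carbonyl carbon, with an at least 2.2-fold higher number from compound 2 to compound 3 (0.34 log units; beyond the scatter). Against 4-nitrophenyl the gap grows to an at least 40-fold higher number from compound 1 to compound 3 (1.60 log units; beyond the scatter), so the three groups now fall in a clear order at this position, with 4-nitrophenyl giving the lowest number and cyclopentylmethyl the highest.

Going by these compounds, how far beyond its limit compound 3 lies remains open, and with it the full size of both steps. Also open, on these data alone, is whether the aromatic ring or the nitro group of 4-nitrophenyl accounts for the lower number of compound 1, a question that an unsubstituted phenyl or a 4-aminophenyl on the carbonyl carbon would address.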